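The compounds below may be only part of what the source reports. "The series", "measured", "known", "first", "only" and "open" are said of these compounds alone.

Measured so far:
compound 1, `COc1ccc2nc(C)cc(OCC(=O)Nc3cc(C)c(OC)c(C)c3)c2c1`: 17000 nM
compound 2, `COc1ccc2nc(C)cc(OCC(=O)Nc3cc(C)c(F)c(C)c3)c2c1`: 31500 nM

In a physicochemical assay for solubility, in phosphate buffer, measured as kinetic solubility, with a stated time of 1 h, at pH 7.4 (a higher number here means a more soluble compound, a lower number a less soluble compound), compound 2 holds the highest of the two numbers, though its nearest neighbour compound 1 sits within the scatter of it, so no order between them can be read. Among the measured compounds shown here, the one measured step, a 1.9-fold higher number from compound 1 to compound 2 (0.27 log units; within the scatter), concerns a fluoro in place of methoxy on an aromatic carbon and stays within the scatter.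

Compound 3, `COc1ccc2nc(C)cc(OCC(=O)Nc3c(C)cncc3C)c2c1`, is not yet measured. It differs from compound 2 by 3,5-dimethylpyridin-4-yl in place of 4-fluoro-3,5-dimethylphenyl on an amide-type nitrogen. For the measured compounds named here, no measured step touches this kind of change, a heteroatom entering the ring attached to the amide-type nitrogen, so the single step on record gives no direct guide. The expectation for compound 3 is a number somewhat higher than that of compound 2, a 1.9-fold higher number from compound 2 to compound 3 (0.28 log units; within the scatter), with wide uncertainty. Compound 3 is estimated at 60000 nM, in the range 25000 nM to 150000 nM.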

Compound 3, solubility: 12000 nM
Compound 3: middle estimate off by 5.0-fold (0.70 log units), on the high side; the measured number lies below the stated range.
By their numbers in this assay, from the lowest: compounds 3, 1 and 2 (each within the scatter of the next, the first and the last beyond it).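

In this assay, among the compounds shown here, the swap of 4-fluoro-3,5-dimethylphenyl for 3,5-dimethylpyridin-4-yl on the amide-type nitrogen gives a 2.6-fold lower number from compound 2 to compound 3 (0.42 log units; beyond the scatter) and is the first step to lie beyond the scatter. The group on the amide-type nitrogen is therefore a place where this read-out can move, and in this single pair the aromatic ring with a hetero atom goes with the lower number. Nothing at hand explains the drop.

As far as these compounds go, this pair changes the ring atom and removes the fluorine together, so the share of each in the step stays open. Also open, from the compounds shown here alone, is how this assay would read for a phenyl ring on the amide-type nitrogen carrying an amine or a carboxylic acid in place of the fluorine.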